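The source may hold more compounds than are shown below. What is called first, only, known or untested is meant among the compounds shown, and "the series" means these compounds.

Going by the values given here, compound 1 `CC(C)(C)C1=NN(c2ccc(Br)cc2)C(c2ccc(O)cc2)C1` gives 93.2% in an assay on isolated protein for inhibition of protein kinase C zeta type (Homo sapiens), with a stated time of 4 min, tested at 62.5 uM (a higher number here means more inhibition at the concentration tested (going by the name of the read-out), a lower number less inhibition), the highest of the three numbers measured so far. Compound 2 `Cc1cccc(N2N=C(C(C)(C)C)CC2c2ccc(O)cc2)c1` gives 91.7% in this assay, and the step of a number 1.5 percentage points lower from compound 1 to compound 2 (within the scatter) lies within the scatter. Compound 3 `CC(C)(C)C1=NN(c2ccc(Cl)cc2Cl)C(c2ccc(O)cc2)C1` gives 71% in this assay, so the step of a number 22.2 percentage points lower from compound 1 to compound 3 (beyond the scatter) is a modest drop. Compound 4 `CC(C)(C)C1=NN(c2ccc(F)c(Cl)c2)C(c2ccc(O)cc2)C1` has not yet been measured. It differs from compound 1 by 3-chloro-4-fluorophenyl in place of 4-bromophenyl on an amine nitrogen in a ring. Both earlier steps change the same aromatic ring on the ring nitrogen: the step of a number 1.5 percentage points lower from compound 1 to compound 2 (within the scatter) did little, while the step of a number 22.2 percentage points lower from compound 1 to compound 3 (beyond the scatter) lowered inhibition modestly. A small decrease is therefore expected, a number 8.2 percentage points lower from compound 1 to compound 4 (within the scatter). Compound 4 is estimated at 85% in this assay, within a range from 70% to 95%.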

Compound 4, a percentage reported as inhibition, at one concentration (the size of the read-out at that concentration, not a potency): 98.8%
Beside the measured number, compound 4's estimate is 13.8 percentage points below it; measured number above the stated range.
By their numbers in this assay, from the lowest: compound 3; then compounds 2, 1 and 4 (each within the scatter of the next).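

In this assay compound 4 shows that two halogens on this phenyl ring can leave inhibition intact, with the step of a number 5.6 percentage points higher from compound 1 to compound 4 (within the scatter) and the step of a number 7.1 percentage points higher from compound 2 to compound 4 (within the scatter) both small. The step of a number 27.8 percentage points higher from compound 3 to compound 4 (beyond the scatter) shows that having two halogens does not settle the outcome, although these two rings differ in both the kind and the placement of their halogens. Nothing measured here explains that gap. Going by these compounds, whether a methoxy group or an amine on this phenyl ring would preserve inhibition stays open. So does whether the two halogen changes in compound 4 matter separately.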